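The source may report more compounds than this note shows. Statements on the series, on what has been measured and on what is new or still open speak of the compounds shown alone.

Going by the values given here, compound 1 `CCC(=O)c1ccc2c(c1)sc(=O)n2CCN1CCCC1` is the weaker of the two measured members of this small set. In an assay on isolated protein (Cavia porcellus) with Sigma non-opioid intracellular receptor 1 (Homo sapiens) as the target, read by radioligand binding (a higher number here means a weaker inhibitor, a lower number a stronger inhibitor), compound 1 gives 571 nM, the highest of the two numbers recorded so far. Among the compounds with values here, its nearest neighbour, compound 2 `CCC(=O)c1ccc2c(c1)sc(=O)n2CCN1CCCCC1`, differs only on the saturated chain carbon, and in this assay compound 2 gives 47 nM; the step of a 12-fold lower number from compound 1 to compound 2 (1.08 log units; beyond the scatter) is the only measured step available. Compound 3 `O=C(c1ccccc1)c1ccc2c(c1)sc(=O)n2CCN1CCCC1` departs from compound 1 in another place: phenyl in place of ethyl on a carbonyl carbon. Within the data shown here, the one measured step concerns the saturated chain carbon two bonds along the chain from the aromatic nitrogen, not the carbonyl carbon, so it does not bear on this change, and the data hold no step at the carbonyl carbon at all. With nothing to point in either direction, the step of a 1.3-fold lower number from compound 1 to compound 3 (0.10 log units; within the scatter) is expected to stay within the scatter, though the range around it must be wide. Compound 3 is therefore estimated at 450 nM in this assay, with a range from 80 nM to 2500 nM.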

Compound 3, inhibition constant: 54 nM
For compound 3 the middle estimate is 8.3-fold (0.92 log units) above the measured one, and the stated range ends above it.
By their numbers in this assay, from the lowest: compounds 2 and 3 (each within the scatter of the next); then compound 1.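

At the carbonyl carbon, the data now hold a measured step: in this assay, phenyl in place of ethyl, the same difference as propanoyl to benzoyl, gives an 11-fold lower number from compound 1 to compound 3 (1.02 log units; beyond the scatter), so what this carbonyl carbon carries clearly matters to the number. Going by these compounds alone, until now the only measured step lay on the saturated chain carbon, whereas this result shows that a large step can also arise at a separate place on the core of compound 1. No available evidence accounts for the size of this step.

From the compounds shown here alone, one change of group at this place cannot separate the effect of the ring from that of the larger count of carbons, so it stays open whether cyclohexyl on the carbonyl carbon would behave as phenyl does, or whether a longer chain such as butyl would do the same. Going by these compounds, it also stays open whether benzoyl and piperidin-1-yl, each tested here only as a single change from compound 1, would add up when carried together by one compound.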